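The source may report more compounds than this note shows. Statements on the series, on what has been measured and on what is new or still open speak of the compounds shown alone.

Measured so far in a physicochemical assay for solubility, in phosphate buffer, at pH 7.4; a lower number here means a less soluble compound, a higher number a more soluble compound:

- compound 1 `CCOC(=O)c1c(-c2ccc(C(C)(C)C)cc2)[nH]c2cccc(OC)c2c1=O`: 1000 nM
- compound 2 `CCOC(=O)c1c(-c2ccccc2)[nH]c2cccc(OC)c2c1=O`: > 100000 nM
- compound 3 `CCOC(=O)c1c(-c2ccc(OC)cc2)[nH]c2cc(OC)ccc2c1=O`: 8000 nM

The value of compound 2 is a limit of the assay and not a number. Its place on the scale is the limit of > 100000 nM in this assay, at which 1 of the 3 values shown sits.

The next compound, compound 4 `CCOC(=O)c1c(-c2cccc(C)c2)[nH]c2cccc(OC)c2c1=O`, carries one change from compound 2: methyl in place of hydrogen on an aromatic carbon. This is methyl in place of hydrogen on an aromatic carbon, or phenyl to 3-methylphenyl.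

Within the data shown here, one measured step bears on this change: an at least 100-fold higher number from compound 1 to compound 2 (2.00 log units; beyond the scatter). It is large and also swaps hydrogen with a carbon group on an aromatic carbon, with the lower number belonging to compound 1, which carries tert-butyl. Among the measured compounds shown here, compound 3 differs from compound 2 in more than one place, so it offers no clean step.

Methyl is a much smaller group than tert-butyl, so a move towards a lower number is expected, but a smaller move than that one. The expected change is an at least 3.3-fold lower number from compound 2 to compound 4 (0.52 log units; beyond the scatter). For compound 4 the estimated value is 30000 nM, within an expected range of 7000 nM to 100000 nM.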

Compound 4, solubility: > 100000 nM
Compound 4: no number, only a limit (the forecaster's own chance of this, stated with the estimate: 30%); middle value at least 3.3-fold (0.52 log units) from the limit.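

In this assay compound 4 gives > 100000 nM, which is a limit and not a number. Compound 2 also sits at a limit, so no step can be read between compound 2 and compound 4: the limit of > 100000 nM in this assay, at which 2 of the 4 values shown sit.

The compounds shown leave open how far, if at all, methyl in place of hydrogen on an aromatic carbon moves the number.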